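The compounds below may be only part of what the source reports. "The series", "measured", "known", "first", "only" and "open" are said of these compounds alone.

Measured so far:
Compound 1, `Cc1ccc(CNC(=O)C(=O)N[C@@H](C)C(=O)N[C@@H](CC(=O)O)C(=O)COc2c(F)c(F)cc(F)c2F)cc1`, gives 50 nM in a functional assay on Jurkat cells (Homo sapiens); a higher number here means a weaker inhibitor, a lower number a stronger inhibitor.
Compound 2, `C[C@H](NC(=O)C(=O)NCc1cccc(F)c1)C(=O)N[C@@H](CC(=O)O)C(=O)COc1c(F)c(F)cc(F)c1F`, gives 106 nM in this assay.
Compound 3, `Cc1cccc(CNC(=O)C(=O)N[C@@H](C)C(=O)N[C@@H](CC(=O)O)C(=O)COc2c(F)c(F)cc(F)c2F)c1C`, gives 102 nM in this assay.

All three share one core and differ only in the aromatic ring that sits on a saturated chain carbon bound to an amide-type nitrogen. On the numbers shown, compound 3 stands second highest of the three. Its nearest neighbour is compound 2: a 1.0-fold lower number from compound 2 to compound 3 (0.02 log units; within the scatter), a gap within the scatter, so the two cannot be ordered. Its furthest neighbour is compound 1: a 2.0-fold higher number from compound 1 to compound 3 (0.31 log units; beyond the scatter), a modest step beyond the scatter.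

Compound 4, `C[C@H](NC(=O)C(=O)NCc1cc(F)cc(F)c1)C(=O)N[C@@H](CC(=O)O)C(=O)COc1c(F)c(F)cc(F)c1F`, has not yet been measured in this assay. Its difference from compound 3 is 3,5-difluorophenyl in place of 2,3-dimethylphenyl on a saturated chain carbon bound to an amide-type nitrogen.

Within the data shown here, two measured steps bear on this change. The swap of a 3-fluorophenyl for the 2,3-dimethylphenyl left the number unchanged within the scatter (a 1.0-fold lower number from compound 2 to compound 3 (0.02 log units; within the scatter)), and both rings gave similar modest losses against compound 1 (a 2.1-fold higher number from compound 1 to compound 2 (0.33 log units; beyond the scatter); a 2.0-fold higher number from compound 1 to compound 3 (0.31 log units; beyond the scatter)). Among the measured compounds shown here, a second fluorine on the ring has no measured counterpart here, so the expectation rests on those steps alone: compound 4 is estimated to show a 1.1-fold higher number from compound 3 to compound 4 (0.03 log units; within the scatter), that is, no step beyond the scatter. The estimate for compound 4 is 110 nM, with a range from 50 nM to 250 nM.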

Compound 4, half-maximal inhibitory concentration: 16 nM
Estimate against measurement, compound 4: 6.9-fold (0.84 log units) above; measured number below the stated range.
By their numbers in this assay, from the lowest: compound 4; then compound 1; then compounds 3 and 2 (each within the scatter of the next).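

This ring position turns out to be more sensitive than the first three compounds suggested. In this assay, the 3,5-difluorophenyl ring gives the strongest inhibitor of the four, outdoing both the 2,3-dimethylphenyl ring (a 6.4-fold lower number from compound 3 to compound 4 (0.80 log units; beyond the scatter)) and the 4-methylphenyl ring, the best of the earlier rings (a 3.1-fold lower number from compound 1 to compound 4 (0.49 log units; beyond the scatter)). Among these compounds, the cleanest comparison is with compound 2, where the only change is fluoro in place of hydrogen on an aromatic carbon (a 6.6-fold lower number from compound 2 to compound 4 (0.82 log units; beyond the scatter)), so a ring with one fluorine gives a weaker inhibitor than compound 1 while a ring with two gives a stronger one, though no measurement here accounts for that turn.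

The four compounds cannot show whether fluorine itself matters or whether any two groups placed as in the 3,5-difluorophenyl ring would serve as well, a question that 3,5-dichlorophenyl or 3,5-dimethylphenyl rings would address. They also leave open how far the trend runs, for instance to a 3,4,5-trifluorophenyl ring, and whether it would hold with a methoxy group on the ring.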